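The source may report more compounds than this note shows. Statements on the series, on what has been measured and on what is new or still open speak of the compounds shown alone.

Series so far:
- compound 1 `O=C(NC1CCCCC1)Oc1ccc(Cl)cc1C(=O)Nc1ccc(F)cc1` gives 8600 nM
- compound 2 `O=C(Nc1ccccc1)Oc1ccc(Cl)cc1C(=O)Nc1ccc(Cl)cc1` gives 900 nM

In an ADME assay on HepG2 cells (Homo sapiens), read by MTT assay, with a stated time of 72 h, in the presence of a further agent that is not named here (a lower number here means a stronger inhibitor, a higher number a weaker inhibitor), compound 2 has the lower of the two numbers (900 nM) and compound 1 lies above it, a gap beyond the scatter.

The next compound is compound 3 `O=C(NC1CCCCC1)Oc1ccc(Cl)cc1C(=O)Nc1ccc(Cl)cc1`. Relative to compound 2 the change is cyclohexyl in place of phenyl on an amide-type nitrogen.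

Among the compounds with values here, no two measured compounds differ in one place only, so the size of this change has not been measured on its own. Compound 1 also carries cyclohexyl on the amide-type nitrogen and gives 8600 nM in this assay, while compound 2, with phenyl there, gives 900 nM in the same test. These two compounds differ in more than one place, so this is only a loose guide. A move to a higher number, meaning a weaker inhibitor, is expected, probably beyond the scatter but smaller than the gap between these two compounds.

The expected change is a 3.3-fold higher number from compound 2 to compound 3 (0.52 log units; beyond the scatter) as estimated here.

For compound 3 the estimated value is 3000 nM with an expected range from 1000 nM to 9000 nM in this test.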

Compound 3, half-maximal inhibitory concentration: 33600 nM
Compound 3: middle estimate off by 11-fold (1.05 log units), on the low side; the whole stated range lies below it.
By their numbers in this assay, from the lowest: compound 2; then compound 1; then compound 3.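

In this assay, cyclohexyl in place of phenyl on the amide-type nitrogen, with the rest of the molecule unchanged, gives a 37-fold higher number from compound 2 to compound 3 (1.57 log units; beyond the scatter) and so is a large step at this position. With cyclohexyl held on that nitrogen, chloro in place of fluoro on an aromatic carbon gives a 3.9-fold higher number from compound 1 to compound 3 (0.59 log units; beyond the scatter) as a modest step, which shows that the halogen also moves the number, here with chloro on the weaker side. The earlier gap between compound 1 and compound 2 therefore combined two changes acting in opposite directions, with the change on the nitrogen the larger of the pair in this one comparison.

On these data alone, it remains open whether the chloro and fluoro step has the same direction with phenyl on the nitrogen, and whether a benzyl group, a pyridyl ring or an open butyl chain on that nitrogen would sit nearer to phenyl or to cyclohexyl. No measurement at hand accounts for either step.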